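Moving the methoxy group on the thiosemicarbazone arylamine

The source may report more compounds than this note shows. Statements on the series, on what has been measured and on what is new or still open speak of the compounds shown alone.

compound 1 `COc1ccccc1NC(=S)N/N=C/c1ccc2ccccc2n1` — > 100000 nM
compound 2 `CN(C)C(=S)N/N=C/c1cnc2ccccc2n1` — 450 nM

In a functional assay on HT-29 cells (Homo sapiens) for antiproliferative activity, read by sulforhodamine B assay, with a stated time of 72 h (on this read-out lower numbers stand for stronger inhibition and higher numbers for weaker inhibition), compound 1 gives only a limit, > 100000 nM. Its standing in this assay is therefore known only as the limit of > 100000 nM in this assay, at which 1 of the 2 values shown sits. For the measured compounds named here, compound 2 gives 450 nM in this assay, and with no single-change step joining it to compound 1 the two values are simply set side by side. Compound 3 `COc1cccc(NC(=S)N/N=C/c2ccc3ccccc3n2)c1` differs from compound 1 by 3-methoxyphenyl in place of 2-methoxyphenyl on an amide-type nitrogen. Going by the values given here, no measured step covers this change. A small gain in this assay is expected, an at least 1.6-fold lower number from compound 1 to compound 3 (0.22 log units; that floor lies within the scatter). Compound 3 is expected to give 60000 nM, between 10000 nM and 200000 nM.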

Compound 3, half-maximal inhibitory concentration: 82400 nM
Compound 3: the middle estimate sits 1.4-fold (0.14 log units) below what was measured; the measured number falls inside the stated range.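

Placing 3-methoxyphenyl in place of 2-methoxyphenyl on the amide-type nitrogen gives a measurable number in this assay where only a limit stood before, with an at least 1.2-fold lower number from compound 1 to compound 3 (0.08 log units; that floor lies within the scatter). The true size of the step cannot be read, because compound 1 is known only as a limit: the limit of > 100000 nM in this assay, at which 1 of the 3 values shown sits. The compounds shown leave open what 4-methoxyphenyl on the same nitrogen would give in this assay. They also leave open whether an unsubstituted phenyl, or an aminophenyl group, would give a lower number there.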